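This account rests on a few compounds, and the source may have more. Where it says the series, first, only, none or still open, it means among the compounds named here.

Compound 1, `CCCCSc1nc(N)nc2c1ncn2/C=C1/CC1(CO)CO`, is the starting point of this account. In an ADME assay on MOLT-3 cells (Homo sapiens) for cytotoxicity, with a stated time of 7 days (on this read-out lower numbers stand for higher toxicity in this test and higher numbers for lower toxicity in this test), compound 1 gives only a limit, > 20000 nM. Compound 2, `Nc1nc(NCc2ccccc2)c2ncn(/C=C3/CC3(CO)CO)c2n1`, likewise reaches only a limit in this assay, at > 20000 nM. Compound 3, `CCCCCCCCSc1nc(N)nc2c1ncn2/C=C1/CC1(CO)CO`, also stops at a limit in this assay, > 20000 nM. The steps among these three, a step that the two limits leave unreadable from compound 1 to compound 2, a step that the two limits leave unreadable from compound 1 to compound 3 and a step that the two limits leave unreadable from compound 2 to compound 3, cannot be read for size because of the limit of > 20000 nM in this assay, at which 3 of the 3 values shown sit. The change now in view leads to compound 4, `COCCOc1nc(N)nc2c1ncn2/C=C1/CC1(CO)CO`, and is 2-methoxyethoxy in place of butylsulfanyl on an aromatic carbon. For the measured compounds named here, none of the measured steps yields a readable size, so the only guide is that every measured compound sits at the same limit. Compound 4 is therefore expected to behave the same way, with the step that the limit leaves unreadable from compound 1 to compound 4 expected to stay within the scatter, and the likeliest outcome is again a limit rather than a number. The estimate for compound 4 is 30000 nM, between 15000 nM and 80000 nM.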

Compound 4, half-maximal cytotoxic concentration: > 20000 nM
Compound 4 ended at the assay's limit (the forecaster's own chance of this, stated with the estimate: 85%); the middle value lies beyond the limit too.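

The steps from compound 4 to compound 1, compound 2 and compound 3 in this assay cannot be read for size, because all of them meet the same obstacle: the limit of > 20000 nM in this assay, at which 4 of the 4 values shown sit.

The compounds shown leave open whether any of these groups on the shared core changes toxicity in this assay.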